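A few compounds are considered here, and "the series" means these few. Any claim that something is new, unique, unknown or untested is made for them only; others in the source may bear on it.

In a functional assay on LoVo cells (Homo sapiens) for inhibition, read by MTT assay, with a stated time of 72 h (a lower number here means a stronger inhibitor, a higher number a weaker inhibitor), compound 1 `Cc1noc(C)c1-c1cnc(N)c(Oc2ccc(C(=O)NC3CC3)cc2)n1` gives > 100000 nM, a limit and not a number. Compound 2 `Cc1noc(C)c1-c1cnc(N)c(Oc2ccc(C(=O)Nc3ccccc3Cl)cc2)n1` gives > 100000 nM, also a limit. Both compounds stand at the same limit: the limit of > 100000 nM in this assay, at which 2 of the 2 values shown sit. Within the data shown here, the only measured step, a step that the two limits leave unreadable from compound 1 to compound 2, has no readable size and offers nothing to scale from. Compound 3 `Cc1noc(C)c1-c1cnc(N)c(Oc2ccc(C(=O)Nc3ccc(Cl)cn3)cc2)n1` carries 5-chloropyridin-2-yl in place of 2-chlorophenyl on an amide-type nitrogen. No step beyond the scatter is expected in this assay, in either direction, and the estimated change is a number no higher from compound 2 to compound 3 (the limit leaves the size open). Compound 3 is expected at 100000 nM, with an estimated range of 30000 nM to 300000 nM.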

Compound 3, half-maximal inhibitory concentration: 9180 nM
Compound 3: the middle estimate sits 11-fold (1.04 log units) above what was measured; measured number outside the range, below it.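

In this assay, the group on the amide-type nitrogen now shows a readable effect: 5-chloropyridin-2-yl gives an at least 10-fold lower number from compound 2 to compound 3 (1.03 log units; beyond the scatter), and an at least 10-fold lower number from compound 1 to compound 3 (1.03 log units; beyond the scatter). The swap from 2-chlorophenyl brings in a ring nitrogen and moves the chlorine at once, so the step cannot be assigned to either change. Compound 1 and compound 2 remain limits and not numbers: the limit of > 100000 nM in this assay, at which 2 of the 3 values shown sit.

On these data alone, how much the chlorine contributes remains open. Pyridin-2-yl without chlorine and 4-chlorophenyl on the same nitrogen would separate the two changes.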